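Swapping a hydroxyphenyl for a methoxyphenyl on the hydrazone

The source may report more compounds than this note shows. Statements on the series, on what has been measured and on what is new or still open speak of the compounds shown alone.

Compound 1, `O=C(COc1cccc2ccccc12)N/N=C/c1cccc(O)c1`, sits at the top of the two readable numbers in an ADME assay on HEL cells (Homo sapiens) for cytotoxicity (on this read-out higher numbers stand for lower toxicity in this test and lower numbers for higher toxicity in this test), where compound 1 gives 100 ug/mL. Compound 2, `C/C(=N\NC(=O)COc1cccc2ccccc12)c1ccc(C#N)cc1Br`, gives 20 ug/mL in this assay, a gap beyond the scatter. Compound 3, `O=C(COc1cccc2ccccc12)N/N=C/c1cccc([N+](=O)[O-])c1`, reaches only the limit of >= 20 ug/mL in this assay, and so the step that the limit leaves unreadable from compound 1 to compound 3 stays unreadable, as the limit of >= 20 ug/mL in this assay, at which 1 of the 3 values shown sits, shows. Compound 4, `COc1ccc(/C=N/NC(=O)COc2cccc3ccccc23)cc1`, differs from compound 1 by 4-methoxyphenyl in place of 3-hydroxyphenyl on a carbon with a double bond to nitrogen. For the measured compounds named here, no measured step touches this change, so no direction can be read from the data; the expectation is a step of no change at the digits printed from compound 1 to compound 4 (within the scatter), that is, none beyond the scatter. Compound 4 is therefore estimated at 100 ug/mL in this assay, between 20 ug/mL and 100 ug/mL.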

Compound 4, minimum cytotoxic concentration: 20 ug/mL
The estimate for compound 4 lay 5.0-fold (0.70 log units) above the measured number, within the range that was stated.
By their numbers in this assay, from the lowest: compounds 2 and 4 (each within the scatter of the next); then compound 1.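

For the compounds shown here, replacing 3-hydroxyphenyl with 4-methoxyphenyl on a carbon with a double bond to nitrogen gives, in this assay, a 5.0-fold lower number from compound 1 to compound 4 (0.70 log units; beyond the scatter), the first readable step at this place, which therefore does not leave the number unchanged. The change alters the group and its ring position together, so this single step cannot separate the two. Nothing measured here gives a cause for the step.

The compounds shown leave open how 3-methoxyphenyl or 4-hydroxyphenyl would read at this place, and what an amine or a carboxylic acid on this ring would do.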